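The compounds below may be only part of what the source reports. "The series", "measured", "known", "first", "only" and "open" are said of these compounds alone.

In a functional assay on HT-29 cells (Homo sapiens) for cytotoxicity, read by sulforhodamine B assay (on this read-out higher numbers stand for weaker inhibition of growth and lower numbers for stronger inhibition of growth), compound 3, with the structure `CC1=CC[C@@H]([C@@](C)(O)CCCC(C)(C)NC(=S)N/N=C\c2ccc(O)cc2)CC1`, gives 31500 nM. Among the numbers shown it sits at the low end, with compound 2, `CC1=CC[C@@H]([C@@](C)(O)CCCC(C)(C)NC(=S)N/N=C\c2ccccc2)CC1`, closest at 36500 nM; the step of a 1.2-fold lower number from compound 2 to compound 3 (0.06 log units; within the scatter) is within the scatter, so the two cannot be ranked. Compound 1, `CC1=CC[C@@H]([C@@](C)(O)CCCC(C)(C)NC(=S)NN)CC1`, gives only a limit in this assay, > 100000 nM, as the limit of > 100000 nM in this assay, at which 1 of the 3 values shown sits, records. From there, adding an aromatic ring to the hydrazine end brings the steps of an at least 2.7-fold lower number from compound 1 to compound 2 (0.43 log units; beyond the scatter) and an at least 3.1-fold lower number from compound 1 to compound 3 (0.50 log units; beyond the scatter).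

Compound 4, `CC1=CC[C@@H]([C@@](C)(O)CCCC(C)(C)NC(=S)N/N=C\c2ccccc2[N+](=O)[O-])CC1`, differs from compound 3 in one place: 2-nitrophenyl in place of 4-hydroxyphenyl on a carbon with a double bond to nitrogen. For the measured compounds named here, the only step that bears directly on a change to this ring is a 1.2-fold lower number from compound 2 to compound 3 (0.06 log units; within the scatter), which did not leave the scatter; the larger steps from compound 1 came from attaching the ring at all, not from what sits on it. The step of a 1.1-fold lower number from compound 3 to compound 4 (0.02 log units; within the scatter) is therefore expected to stay within the scatter. Compound 4 is estimated at 30000 nM, with a range from 12000 nM to 80000 nM.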

Compound 4, concentration for total growth inhibition: 16800 nM
Compound 4: the middle estimate sits 1.8-fold (0.25 log units) above what was measured, and the stated range covers the measured number.
By their numbers in this assay, from the lowest: compounds 4, 3 and 2 (each within the scatter of the next, the first and the last beyond it). At a limit, above all of these: compound 1.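

For the compounds shown here, on the ring attached to the carbon with a double bond to nitrogen, the step of a 2.2-fold lower number from compound 2 to compound 4 (0.34 log units; beyond the scatter) is the first change to that ring that goes beyond the scatter, though only modestly; the hydroxy group of compound 3 had not done so. So what sits on the ring, and not only the presence of the ring, can shift the number in this assay. The step of a 1.9-fold lower number from compound 3 to compound 4 (0.27 log units; within the scatter) stays within the scatter, however, so 2-nitrophenyl and 4-hydroxyphenyl cannot be ranked against each other, and nothing shown explains the effect of the nitro group.

The compounds shown leave open whether this shift belongs to the nitro group in particular. An amine, a carboxylic acid or a methoxy group in its place would help to test that.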